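Bromo to trifluoromethyl at the limit of the series

A few compounds are considered here, and "the series" means these few. Any claim that something is new, unique, unknown or untested is made for them only; others in the source may bear on it.

In an ADME assay on MDBK cells (Bos taurus) for cytotoxicity, read by MTT assay, with a stated time of 72 h (on this read-out higher numbers stand for lower toxicity in this test and lower numbers for higher toxicity in this test), compound 3 `Brc1ccc(NCc2cn(-c3ccccc3)nc2-c2ccc(Br)cc2)cc1` gives > 100000 nM, which is a limit and not a number. Compound 1 `Cc1ccc(NCc2cn(-c3ccccc3)nc2-c2ccc(C(F)(F)F)cc2)cc1` gives > 100000 nM, also a limit. Compound 2 `FC(F)(F)c1ccc(NCc2cn(-c3ccccc3)nc2-c2ccc(C(F)(F)F)cc2)cc1` gives 26000 nM.

Compound 4 `FC(F)(F)c1ccc(-c2nn(-c3ccccc3)cc2CNc2ccc(Br)cc2)cc1` differs from compound 3 by trifluoromethyl in place of bromo on an aromatic carbon: trifluoromethyl in place of bromo, read further out as 4-bromophenyl to 4-(trifluoromethyl)phenyl. Within the data shown here, the only measured step, an at least 3.8-fold lower number from compound 1 to compound 2 (0.58 log units; beyond the scatter), also brought in trifluoromethyl, but in place of methyl and at a different place. It therefore bears only indirectly. Compound 1 already carries the 4-(trifluoromethyl)phenyl group.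

A modest move to a lower number in this assay is expected, shown as an at least 1.6-fold lower number from compound 3 to compound 4 (0.22 log units; that floor lies within the scatter). The estimated value for compound 4 is 60000 nM, with an expected range of 20000 nM to 100000 nM.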

Compound 4, half-maximal cytotoxic concentration: 64000 nM
The estimate for compound 4 lay 1.1-fold (0.03 log units) below the measured number, within the range that was stated.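

In this assay, among these compounds, bromo in place of trifluoromethyl on an aromatic carbon gives a 2.5-fold higher number from compound 2 to compound 4 (0.39 log units; beyond the scatter), the first step with a true number at both ends. This shows that the group at this place can move the number beyond the scatter. The other two steps, an at least 1.5-fold lower number from compound 3 to compound 4 (0.19 log units; that floor lies within the scatter) and an at least 1.5-fold lower number from compound 1 to compound 4 (0.19 log units; that floor lies within the scatter), give only floors within the scatter, because their starting compounds sit at a limit: the limit of > 100000 nM in this assay, at which 2 of the 4 values shown sit.

On these data alone, the true size of those two changes stays open. So does the effect on this number of an amine or a carboxylic acid at this place.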